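From compound 3 to compound 4: chloro gives way to fluoro

A few compounds are considered here, and "the series" means these few. Any claim that something is new, unique, unknown or untested is made for them only; others in the source may bear on it.

Of the compounds shown here, three have been measured in an ADME assay on microsomes from liver (Homo sapiens) for metabolic stability, tested at 2.5 uM; a lower number here means slower removal, a higher number faster removal of the compound. Compound 1 `O=S(=O)(c1ccc(F)c(F)c1)c1cnc2c(F)cccc2c1-c1ccc(Cl)cc1` gives 0.28 mL/min, compound 2 `O=S(=O)(c1ccc(F)cc1)c1cnc2c(F)cccc2c1-c1cccc(F)c1` gives 1.56 mL/min, and compound 3 `O=S(=O)(c1ccc(F)c(Cl)c1)c1cnc2c(F)cccc2c1-c1cccc(F)c1` gives 1.23 mL/min. Compound 3 thus stands second highest of the three, close to compound 2 and well apart from compound 1. Among the measured compounds shown here, the only single-point step among them, a 1.3-fold lower number from compound 2 to compound 3 (0.10 log units; within the scatter), hardly moved the number. Compound 4 `O=S(=O)(c1ccc(F)c(F)c1)c1cnc2c(F)cccc2c1-c1cccc(F)c1` differs from compound 3 by fluoro in place of chloro on an aromatic carbon. For the measured compounds named here, no measured step has this exact change, so the expectation rests on the small move from compound 2 to compound 3 and on the lower number of compound 1, which shares the 3,4-difluorophenyl group. Compound 4 is therefore expected near 1 mL/min, within 0.5 mL/min to 2 mL/min, a step of a 1.2-fold lower number from compound 3 to compound 4 (0.09 log units; within the scatter) that is estimated to stay within the scatter.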

Compound 4, intrinsic clearance in a liver preparation (reported as CLH), per the amount of preparation that the assay uses: 1.28 mL/min
Estimate against measurement, compound 4: 1.3-fold (0.11 log units) below; measured number inside the range.
By their numbers in this assay, from the lowest: compound 1; then compounds 3, 4 and 2 (each within the scatter of the next).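

At this aromatic carbon, fluoro in place of chloro leaves the number within the scatter (a 1.0-fold higher number from compound 3 to compound 4 (0.02 log units; within the scatter)) in this assay, as does fluoro in place of hydrogen (a 1.2-fold lower number from compound 2 to compound 4 (0.09 log units; within the scatter)), so hydrogen, chloro and fluoro here cannot be told apart. With the 3,4-difluorophenyl group held, the step beyond the scatter comes from the other aryl group, 3-fluorophenyl in place of 4-chlorophenyl (a 4.6-fold higher number from compound 1 to compound 4 (0.66 log units; beyond the scatter)). No measurement given here explains these numbers. Still open, on these data alone, is whether a methoxy group or an amine on this carbon would move the number beyond the scatter.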